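The source may report more compounds than this note shows. Statements on the series, on what has been measured and on what is new or still open speak of the compounds shown alone.

Two compounds were tested in a functional assay on BT-549 cells (Homo sapiens) for inhibition, read by sulforhodamine B assay, with a stated time of 48 h, tested at 10 uM; on this read-out lower numbers stand for a stronger effect and higher numbers for a weaker effect at the one concentration tested. Compound 1 `COc1cc(Cl)cc(-c2nn(-c3cccc(NC(=O)c4ccc(Cl)c(Cl)c4)c3)cc2-c2ccncc2)c1` gives 85.2%, while compound 2 `O=C(Nc1cccc(-n2cc(-c3ccncc3)c(-c3cc(O)cc(Cl)c3)n2)c1)Nc1ccc(Cl)c(C(F)(F)F)c1` gives 47.6%, the lower of the two numbers and so the stronger effect at the single concentration, by a margin beyond the scatter. Compound 3 `O=C(Nc1cccc(-n2cc(-c3ccncc3)c(-c3cc(O)cc(Cl)c3)n2)c1)Nc1ccc(Cl)c(Cl)c1` differs from compound 2 in one place: chloro in place of trifluoromethyl on an aromatic carbon. Within the data shown here, no measured pair shows this change, so its effect cannot be read from the data. A small step, expected to stay within the scatter or only just beyond it, is estimated as a number 4.4 percentage points higher from compound 2 to compound 3 (within the scatter). Compound 3 is expected to give about 52%, within a range from 35% to 70%.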

Compound 3, a percentage reported as activity, at one concentration (the size of the read-out at that concentration, not a potency): 0.54%
Compound 3: middle estimate off by 51.5 percentage points, on the high side; measured number outside the range, below it.
By their numbers in this assay, from the lowest: compound 3; then compound 2; then compound 1.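

Swapping one small group at this position matters far more than the earlier compounds could suggest: in this assay, chloro in place of trifluoromethyl gives a number 47.1 percentage points lower from compound 2 to compound 3 (beyond the scatter). On this ring, ortho to a chloro group, the read-out at the one concentration tested is therefore highly sensitive to the group present. Nothing available explains why this step is so large. The compounds shown leave open how a methyl group or an amine would behave at this position. They also leave open whether the same change would have a similar effect on a different compound.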